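Cyclopentyl for oxolanyl on the amine nitrogen

The source may report more compounds than this note shows. Statements on the series, on what has been measured and on what is new or still open speak of the compounds shown alone.

Of the compounds shown here, two carry numbers so far. Compound 1 `CN(c1nc2ccc(NC(=O)CCc3ccc(C(F)(F)F)cc3)cc2[nH]1)C1CCOC1` is the reference point; in an assay on CHO-K1 cells for displacement of a labelled ligand from melanin-concentrating hormone receptor 1 (Homo sapiens), read by scintillation counting (a lower number here means a stronger inhibitor, a higher number a weaker inhibitor), compound 1 gives 27 nM. Compound 2 `CC(C)N(C)c1nc2ccc(NC(=O)c3cncc(-c4ccc(F)cc4)c3)cc2[nH]1`, which differs from compound 1 in several places at once, is the only comparator; in this assay compound 2 gives 900 nM. Compound 1 thus holds the lowest of the two numbers, and its distance from compound 2 lies well beyond the usual scatter.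

The next compound, compound 3 `CN(c1nc2ccc(NC(=O)CCc3ccc(C(F)(F)F)cc3)cc2[nH]1)C1CCCC1`, keeps everything of compound 1 except the ring on the amine: the change reads (cyclopentyl in place of oxolan-3-yl on a nitrogen on an aromatic ring). Among the measured compounds shown here, no comparable single-point step between measured compounds exists, so the size of this step cannot be read off any measured pair.

With the oxolane oxygen gone and the ring otherwise unchanged, the number in this assay is expected to move little, and any shift from compound 1 to compound 3 is expected to be within the scatter, as a 1.1-fold lower number from compound 1 to compound 3 (0.03 log units; within the scatter). Compound 3 is therefore estimated at 25 nM in this assay, with a range from 8 nM to 80 nM.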

Compound 3, half-maximal inhibitory concentration: 4 nM
Estimate against measurement, compound 3: 6.3-fold (0.80 log units) above, and the stated range ends above it.
By their numbers in this assay, from the lowest: compound 3; then compound 1; then compound 2.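

Cyclopentyl in place of oxolan-3-yl on this nitrogen gives the first single-point step of the series: in this assay there is a 6.8-fold lower number from compound 1 to compound 3 (0.83 log units; beyond the scatter), so the number responds to the ring held at this position. The two rings match in heavy-atom count and are both five-membered and non-aromatic, but oxolan-3-yl carries an oxygen and a hydrogen-bond acceptor that cyclopentyl lacks, and the lower number goes with the all-carbon ring in this one pair. Nothing at hand explains the size of the step, so no cause can be assigned to it.

A single pair cannot show whether the ring oxygen alone sets the difference or whether ring size and ring type also matter at this nitrogen; cyclobutyl, cyclohexyl or pyrrolidin-3-yl in the same place would bear on that. On these data alone, it also remains open whether the step carries over to an amide side other than that of compound 1 and compound 3, for instance one with a nitrile in place of the trifluoromethyl group.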